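The source may report more compounds than this note shows. Statements on the series, on what has been measured and on what is new or still open speak of the compounds shown alone.

Working notes on the series. Among the measured compounds shown here, in a functional assay (aorta) with Oryctolagus cuniculus as the target (a higher number here means a weaker inhibitor, a lower number a stronger inhibitor), compound 3 `CCCc1cnc(-c2nn(Cc3ccccc3F)c3ncccc23)nc1N` gives 252000 nM, which places it second highest of the three numbers so far. Its nearest neighbour is compound 2 `Cc1cnc(-c2nn(Cc3ccccc3F)c3ncccc23)nc1N`, which in this assay gives 675000 nM; furthest away is compound 1 `Fc1ccccc1Cn1nc(-c2ncccn2)c2cccnc21`, which in this assay gives 1250 nM. The two measured steps are a 540-fold higher number from compound 1 to compound 2 (2.73 log units; beyond the scatter), the large one, and a 2.7-fold lower number from compound 2 to compound 3 (0.43 log units; beyond the scatter), the modest one.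

Compound 4 `CCCCc1cnc(-c2nn(Cc3ccccc3F)c3ncccc23)nc1N` differs from compound 3 by methyl in place of hydrogen on a saturated chain carbon, three bonds along the chain from an aromatic carbon. For the measured compounds named here, the one measured step that bears on this change is the chain extension from compound 2 to compound 3, where a 2.7-fold lower number from compound 2 to compound 3 (0.43 log units; beyond the scatter) was seen; the large step from compound 1 to compound 2 concerns a different part of the molecule and says nothing direct about the chain. A further extension of the same chain by one carbon is therefore expected to give a step in this assay in the same direction as before but no larger, and it could also fall within the scatter. On that basis compound 4 is expected to give about 150000 nM in this assay, with a range from 60000 nM to 400000 nM, which means an expected step of a 1.7-fold lower number from compound 3 to compound 4 (0.23 log units; within the scatter).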

Compound 4, half-maximal inhibitory concentration: 218000 nM
Compound 4: middle estimate off by 1.5-fold (0.16 log units), on the low side, within the range that was stated.
By their numbers in this assay, from the lowest: compound 1; then compounds 4 and 3 (each within the scatter of the next); then compound 2.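

In this assay the change from propyl to butyl gives a 1.2-fold lower number from compound 3 to compound 4 (0.06 log units; within the scatter) and so leaves compound 3 and compound 4 indistinguishable, which shows that adding this methyl, three bonds along the chain from an aromatic carbon, has no readable effect. Taken from the shorter chain of compound 2, the whole extension amounts to a 3.1-fold lower number from compound 2 to compound 4 (0.49 log units; beyond the scatter) and remains a modest step, of similar size to the earlier 2.7-fold lower number from compound 2 to compound 3 (0.43 log units; beyond the scatter) and with no sign that the extra carbon adds to it. Both chain steps are small beside a 540-fold higher number from compound 1 to compound 2 (2.73 log units; beyond the scatter) and do not bring the numbers of this chain series near that of compound 1, so on these compounds the chain at this position is a minor influence in this assay and the flattening begins once the chain reaches propyl.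

On these data alone, it remains open whether a longer chain such as hexyl, a branched chain such as isobutyl, or a chain ending in an amine or a carboxylic acid would move the number further at this position. Nothing measured here explains why the butyl chain adds no readable change over the propyl chain.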